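The compounds below may be only part of what the source reports. "The series", "measured", "known", "first", "only" and "open" are said of these compounds alone.

Compound 1 `COc1ccc([N+](=O)[O-])cc1CSc1nc2cc(NC(=O)NC(C)(C)C)ccc2n1-c1ccccc1`: > 2600 nM
Compound 2 `CCCn1c(SCc2cc([N+](=O)[O-])ccc2OC)nc2cc(NC(=O)NC(C)(C)C)cc(C(=O)NC)c21`: 23 nM

In an assay on isolated protein for inhibition of Gonadotropin-releasing hormone receptor (Rattus norvegicus) (on this read-out lower numbers stand for stronger inhibition and higher numbers for weaker inhibition), compound 1 reaches only a limit of the assay, not a number, standing at > 2600 nM (the limit of > 2600 nM in this assay, at which 1 of the 2 values shown sits). Compound 2 holds the single real number shown: in this assay compound 2 gives 23 nM. Compound 3 `CCCn1c(SCc2cc([N+](=O)[O-])ccc2OC)nc2cc(NC(=O)NC(C)(C)C)cc(C(=O)NCCCN(C)C)c21` differs from compound 2 by 2-(dimethylamino)ethyl in place of hydrogen on a saturated chain carbon bound to an amide-type nitrogen. Among the measured compounds shown here, no measured pair covers a change of this kind, so the account expects no shift in this assay beyond the usual scatter, in either direction. Compound 3 is therefore estimated at 22 nM, with a range from 6 nM to 80 nM. This expected estimate amounts to a step of a 1.0-fold lower number from compound 2 to compound 3 (0.02 log units; within the scatter).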

Compound 3, half-maximal inhibitory concentration: 19 nM
Compound 3: the middle estimate sits 1.2-fold (0.06 log units) above what was measured, and the stated range covers the measured number.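

In this assay, 2-(dimethylamino)ethyl in place of hydrogen on a saturated chain carbon bound to an amide-type nitrogen gives a 1.2-fold lower number from compound 2 to compound 3 (0.08 log units; within the scatter) and so stays within the scatter. This place therefore accepts a chain of 5 heavy atoms ending in a dimethylamino group, and the values of compound 2 and compound 3 cannot be ordered. No measurement shown here bears on why this is so.

On these data alone, whether a carboxylic acid, a morpholine or a longer chain would be accepted at this place stays open. So does whether a primary amine at the chain end would give the same result.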